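Seven-membered ring in place of 4-methylpiperazin-1-yl

The compounds below may be only part of what the source reports. "The series", "measured", "known", "first", "only" and "open" are said of these compounds alone.

- compound 1 `Cc1ccccc1Nc1nc(Nc2ccc(N3CCN(C)CC3)cc2)ncc1Cl`: 20600 nM
- compound 2 `Cc1ccccc1Nc1nc(Nc2ccc(N3CCN(C(=O)OC(C)(C)C)CC3)cc2)ncc1Cl`: 2250 nM

In a functional assay on MCF7 cells (Homo sapiens) for inhibition, read by CCK-8 assay, with a stated time of 48 h (on this read-out higher numbers stand for weaker inhibition of growth and lower numbers for stronger inhibition of growth), compound 1 holds the higher of the two numbers. Compound 3 `Cc1ccccc1Nc1nc(Nc2ccc(N3CCCN(C)CC3)cc2)ncc1Cl` differs from it by 4-methyl-1,4-diazepan-1-yl in place of 4-methylpiperazin-1-yl on an aromatic carbon, with the seven-membered ring taking the place of the six-membered ring on an aromatic carbon. For the measured compounds named here, the one measured step, a 9.2-fold lower number from compound 1 to compound 2 (0.96 log units; beyond the scatter), changes the group on the ring nitrogen and keeps the ring size, so it is only a loose guide. No step beyond the scatter is expected, with a slight lean towards a lower number. The expected step is a 1.4-fold lower number from compound 1 to compound 3 (0.14 log units; within the scatter). For compound 3 the estimated value is 15000 nM, with an expected range of 6000 nM to 40000 nM.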

Compound 3, concentration for 50% growth inhibition: 4290 nM
Beside the measured number, compound 3's estimate is 3.5-fold (0.54 log units) above it; the whole stated range lies above it.
By their numbers in this assay, from the lowest: compounds 2 and 3 (each within the scatter of the next); then compound 1.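

In this assay the size of the ring at this position counts: with the methyl on the ring nitrogen kept, the seven-membered 4-methyl-1,4-diazepan-1-yl gives a 4.8-fold lower number from compound 1 to compound 3 (0.68 log units; beyond the scatter) and so moves the number without any change of that nitrogen's group. The number at this place therefore answers to the ring as well as to its nitrogen substituent. No measurement at hand accounts for this step. Open, on these data alone, is whether a morpholine ring behaves likewise, and whether tert-butoxycarbonyl on the seven-membered ring adds to the ring change.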